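A few compounds are considered here, and "the series" means these few. Any claim that something is new, unique, unknown or untested is made for them only; others in the source may bear on it.

Among the measured compounds shown here, compound 2 `CC(C)C[C@H](N)CN(C(=O)[C@@H]1C[C@H]1c1ccccc1)c1ccc(-c2ccc(Cl)cc2)cc1` carries the lowest of the two numbers measured so far in a functional assay for agonist activity at G protein-coupled receptor 88 (Homo sapiens), read by HTRF and cAMP accumulation; a higher number here means that more compound is needed for the effect, a lower number that less compound is needed; compound 2 gives 640 nM. For the measured compounds named here, its nearest neighbour is compound 1 `CC(C)C[C@H](N)CN(C(=O)[C@@H]1C[C@H]1c1ccccc1)c1ccc(C2=CCCCC2)cc1`, which in this assay gives 1200 nM, and the single measured step, a 1.9-fold lower number from compound 1 to compound 2 (0.27 log units; within the scatter), lies within the scatter.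

Compound 3 `CC(C)C[C@H](N)CN(C(=O)[C@@H]1C[C@H]1c1ccccc1)c1ccc(-c2ccccc2Cl)cc1` differs from compound 2 only at the group on the aromatic carbon para to a large group: 2-chlorophenyl in place of 4-chlorophenyl on an aromatic carbon. Going by the values given here, no measured pair shows a chlorine moved within the same ring; the one step that touches this position, a 1.9-fold lower number from compound 1 to compound 2 (0.27 log units; within the scatter), exchanged a different group entirely and stayed within the scatter. On these two compounds alone, no step beyond the scatter is expected from compound 2 to compound 3 in this assay, and the expected step is a 1.3-fold higher number from compound 2 to compound 3 (0.10 log units; within the scatter). Compound 3 is therefore estimated at 800 nM, with a range from 250 nM to 3000 nM.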

Compound 3, half-maximal effective concentration: 3800 nM
The estimate for compound 3 lay 4.8-fold (0.68 log units) below the measured number; the whole stated range lies below it.
By their numbers in this assay, from the lowest: compounds 2 and 1 (each within the scatter of the next); then compound 3.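

In this assay this position proves sensitive to where the chlorine sits on the ring: 2-chlorophenyl in place of 4-chlorophenyl, with the same atoms and the same counts on both sides, gives a 5.9-fold higher number from compound 2 to compound 3 (0.77 log units; beyond the scatter) and thus a step beyond the scatter, which the earlier pair did not show. The position also separates 2-chlorophenyl from cyclohex-1-en-1-yl, with a 3.2-fold higher number from compound 1 to compound 3 (0.50 log units; beyond the scatter) set against an earlier exchange of groups that stayed within the scatter. No measurement here accounts for the difference between the two chlorophenyl groups.

On these data alone, whether the higher number follows the chlorine itself or any group at that place on the ring remains open. A phenyl carrying a methoxy group or a nitrile in place of the chlorine, or plain phenyl, would bear on that question.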